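Five-membered ring in place of six: compound 3 to compound 4

The source may report more compounds than this note shows. Statements on the series, on what has been measured and on what is new or still open speak of the compounds shown alone.

Three compounds share a core and differ only in the aromatic arm on a saturated chain carbon bound to an amine nitrogen. In a functional assay on CEM-CCRF cells for antagonist activity at C-X-C chemokine receptor type 4 (Homo sapiens), read by calcium flux (a higher number here means a weaker inhibitor, a lower number a stronger inhibitor), compound 1 `COCc1ccc(CN(Cc2nc3ccccc3[nH]2)C2CCCc3cccnc32)c(CN)c1` gives 21 nM, compound 2 `NCc1cc(C(=O)O)ccc1CN(Cc1nc2ccccc2[nH]1)C1CCCc2cccnc21` gives 126 nM, and compound 3 `NCc1ccncc1CN(Cc1nc2ccccc2[nH]1)C1CCCc2cccnc21` gives 160 nM. Compound 3 therefore carries the highest of the three numbers; compound 2 sits within the scatter of it, while compound 1 lies well apart, as seen in a 7.6-fold higher number from compound 1 to compound 3 (0.88 log units; beyond the scatter) and a 1.3-fold higher number from compound 2 to compound 3 (0.10 log units; within the scatter).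

Compound 4 `NCc1sccc1CN(Cc1nc2ccccc2[nH]1)C1CCCc2cccnc21` is the next step: a group of 7 heavy atoms (5 carbon, 1 nitrogen, 1 sulfur; one five-membered aromatic ring with 1 hetero atom) in place of a group of 8 heavy atoms (6 carbon, 2 nitrogen; one six-membered aromatic ring with 1 hetero atom), on a saturated chain carbon bound to an amine nitrogen. Both earlier ring exchanges on this carbon bear on it; one was a 7.6-fold higher number from compound 1 to compound 3 (0.88 log units; beyond the scatter), the other 1.3-fold higher number from compound 2 to compound 3 (0.10 log units; within the scatter), so an exchange of one aromatic arm for another of similar size has moved this assay anywhere from not at all to modestly. Going by the values given here, no step among the measured compounds involves a five-membered ring, so the expectation for compound 4 rests on these two.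

For compound 4 a number close to compound 3 is expected in this assay, about 150 nM, with a range from 50 nM to 450 nM, which means an expected step of a 1.1-fold lower number from compound 3 to compound 4 (0.03 log units; within the scatter), within the scatter.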

Compound 4, half-maximal inhibitory concentration: 60 nM
For compound 4 the middle estimate is 2.5-fold (0.40 log units) above the measured one; the measured number falls inside the stated range.
By their numbers in this assay, from the lowest: compound 1; then compound 4; then compounds 2 and 3 (each within the scatter of the next).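

In this assay, the arm on a saturated chain carbon bound to an amine nitrogen accepts a five-membered aromatic ring with 1 hetero atom, and this exchange separates compound 4 from both arms that stood within the scatter of each other (a 2.7-fold lower number from compound 3 to compound 4 (0.43 log units; beyond the scatter); a 2.1-fold lower number from compound 2 to compound 4 (0.32 log units; beyond the scatter)). The new ring does not match the six-membered aromatic ring of carbon only that carries methoxymethyl, so compound 1 keeps the lowest number in the series (a 2.9-fold higher number from compound 1 to compound 4 (0.46 log units; beyond the scatter)). No measurement available here explains these steps.

The compounds shown leave open whether the gain belongs to sulfur or to ring size, which a five-membered aromatic ring with oxygen as its hetero atom would test. From the compounds shown here alone, whether methoxymethyl on the ring of compound 4 would lower the number further also remains open.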